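The source may hold more compounds than are shown below. What is called first, only, known or untested is meant among the compounds shown, and "the series" means these compounds.

In a functional assay on HeLa cells (Homo sapiens) for antiproliferative activity, read by MTT assay, with a stated time of 48 h (on this read-out higher numbers stand for weaker inhibition and lower numbers for stronger inhibition), compound 1 (`COC(=O)[C@H](C)NC(=O)c1ccc(Oc2nc3ccccc3nc2C)cc1`) gives 32200 nM while compound 2 (`COC(=O)[C@H](CC(C)C)NC(=O)c1ccc(Oc2nc3ccccc3nc2C)cc1`) gives 21600 nM and the two lie within the scatter of each other. Compound 3 (`CC[C@@H](C)[C@H](NC(=O)c1ccc(Oc2nc3ccccc3nc2C)cc1)C(=O)OC`) is still unmeasured and carries sec-butyl in place of isobutyl on a saturated chain carbon bound to an amide-type nitrogen and a carbonyl carbon. Within the data shown here, the one measured step that bears on this (a 1.5-fold lower number from compound 1 to compound 2 (0.17 log units; within the scatter)) stayed within the scatter, so no step beyond the scatter is expected in this assay here. The expected step (a 1.0-fold higher number from compound 2 to compound 3 (0.01 log units; within the scatter)) is therefore small. Compound 3 is estimated at 22000 nM (range 11000 nM to 42000 nM).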

Compound 3, half-maximal inhibitory concentration: > 50000 nM
Compound 3: a limit, no number (the forecaster's own chance of this, stated with the estimate: 5%); middle value at least 2.2-fold (0.35 log units) from the limit.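

In this assay, the branch position on this four-carbon side chain matters even though the atoms stay the same: sec-butyl in place of isobutyl gives an at least 2.3-fold higher number from compound 2 to compound 3 (0.36 log units; beyond the scatter). Against the methyl side chain the picture is looser, with an at least 1.5-fold higher number from compound 1 to compound 3 (0.19 log units; that floor lies within the scatter), so that gap is not established. Compound 3 gives a limit of the assay, not a number: the limit of > 50000 nM in this assay, at which 1 of the 3 values shown sits.

From the compounds shown here alone, whether the shifted branch or the added defined stereocentre matters more stays open. So does the effect of a carboxylic acid in place of the methyl ester, or of an amine on the side chain.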